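Shortening a nitrate-bearing chain by one carbon

The source may report more compounds than this note shows. Statements on the series, on what has been measured and on what is new or still open speak of the compounds shown alone.

Of the compounds shown here, two have been measured in a functional assay on aorta (Rattus norvegicus, strain Wistar) for inhibition, with a stated time of 30 min; a higher number here means that more compound is needed for the effect, a lower number that less compound is needed. Compound 1 `CC(=O)Oc1ccccc1C(=O)OCOC(=O)c1cccc(OCCCO[N+](=O)[O-])c1` gives 140 nM. Compound 2 `O=C(O)CCCCCCO[N+](=O)[O-]` gives 20000 nM, the highest number of the two, far above that of compound 1. Compound 3 `O=C(O)CCCCCO[N+](=O)[O-]` has not been measured yet. It differs from compound 2 in one place: carboxy in place of carboxymethyl on a saturated chain carbon, five bonds along the chain from an oxygen on an unsaturated carbon. Going by the values given here, no measured pair shows what such a change does here, so its effect is unknown. In this assay, compound 3 is expected to give 20000 nM, within a range from 7000 nM to 60000 nM. That estimate means an expected step of no change at the digits printed from compound 2 to compound 3 (within the scatter), not beyond the scatter.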

Compound 3, half-maximal effective concentration: 8300 nM
Compound 3: middle estimate off by 2.4-fold (0.38 log units), on the high side, and the stated range covers the measured number.
By their numbers in this assay, from the lowest: compound 1; then compound 3; then compound 2.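

In this assay, the change from carboxymethyl to carboxy gives a 2.4-fold lower number from compound 2 to compound 3 (0.38 log units; beyond the scatter), a modest step. Going by these compounds alone, this is the first measured pair to show that this chain position responds to such a small change, with one carbon fewer going along with a lower number. Nothing measured here explains why the number falls.

Going by these compounds, a single step cannot show a trend with chain length, so it remains open whether a shorter or longer chain would continue in this direction. On these data alone, how an amine in place of the carboxy group would affect the number also remains open.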